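Compound 3 and the half-life of its parent

The source may report more compounds than this note shows. Statements on the series, on what has been measured and on what is new or still open speak of the compounds shown alone.

Measured in an ADME assay on microsomes from liver (Mus musculus) for metabolic stability; on this read-out higher numbers stand for a longer-lived compound and lower numbers for a shorter-lived compound:
- compound 1 `CCC(CC)(c1nnc[nH]1)c1ccc(-c2ccc3cc(F)cc(F)c3c2)[nH]c1=O`: 1.09 h
- compound 2 `CC(C)C(c1ncco1)c1ccc(-c2ccc3cccc(F)c3c2)[nH]c1=O`: 0.08 h

Of these two, compound 2 has the lower number, 0.08 h, and its gap to compound 1 lies beyond the scatter. The next compound to be read in this assay is compound 3 `CC(C)C(c1nnc[nH]1)c1ccc(-c2ccc3cccc(F)c3c2)[nH]c1=O`, which departs from compound 2 in one place: 4H-1,2,4-triazol-3-yl in place of 1,3-oxazol-2-yl on a saturated chain carbon bound to an aromatic carbon and a saturated chain carbon. In words, 4H-1,2,4-triazol-3-yl stands in place of 1,3-oxazol-2-yl on a saturated chain carbon bound to an aromatic carbon and a saturated chain carbon.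

Among the compounds with values here, no measured pair shows this change alone, so the evidence is indirect. The entering group also occurs in compound 1, which reads 1.09 h, but that compound has other differences too, so only part of the gap is expected to carry over. The expected direction is upward, with an estimated 3.8-fold higher number from compound 2 to compound 3 (0.57 log units; beyond the scatter). For compound 3 the half-life is expected to be about 0.3 h, within an estimated range of 0.12 h to 0.8 h.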

Compound 3, half-life: 0.213 h
Compound 3: the middle estimate sits 1.4-fold (0.15 log units) above what was measured; the measured number falls inside the stated range.
By their numbers in this assay, from the lowest: compound 2; then compound 3; then compound 1.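

In this assay the exchange of the ring on the saturated chain carbon can now be read on its own, and it gives a 2.7-fold higher number from compound 2 to compound 3 (0.43 log units; beyond the scatter) with the rest of the molecule unchanged. This shows that the ring at this position matters for the half-life: 4H-1,2,4-triazol-3-yl in place of 1,3-oxazol-2-yl moves the number beyond the scatter, although both groups are five-membered aromatic rings of 5 heavy atoms, and the entering ring has 1 hydrogen-bond donor where the leaving ring has 0. Nothing at hand accounts for the step, so its cause stays open.

On these data alone, it remains open whether this exchange would give a step of similar size on another scaffold, such as that of compound 1, which carries the same 4H-1,2,4-triazol-3-yl but differs from compound 3 in other places as well. As far as these compounds go, it is also open how other groups in this place, such as a carboxylic acid, a primary amide or a 1,3-thiazol-2-yl ring, would read in this assay on the core shared by compound 2 and compound 3.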